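Methyl in place of methoxy on the shared core

This account rests on a few compounds, and the source may have more. Where it says the series, first, only, none or still open, it means among the compounds named here.

For the measured compounds named here, in a functional assay on C6 cells (Rattus norvegicus) for cytotoxicity, read by MTT assay, with a stated time of 24 h, tested at 25 ug/mL (on this read-out higher numbers stand for a weaker effect at the one concentration tested and lower numbers for a stronger effect), compound 1 `O=C(CSc1ncccn1)N/N=c1/scc(-c2ccc(Br)cc2)n1-c1ccccc1` gives 72.3% and compound 2 `O=C(CSc1ncccn1)N/N=c1/scc(-c2ccc(F)cc2)n1-c1ccccc1` gives 63.9%; the only step measured so far, a number 8.4 percentage points lower from compound 1 to compound 2 (within the scatter), is small. Compound 3 `COc1ccc(-c2cs/c(=N/NC(=O)CSc3nnc(C)s3)n2-c2ccccc2)cc1` gives 42.6%, the lowest of the three numbers, beyond the scatter from both others. Compound 4 `Cc1ccc(-c2cs/c(=N/NC(=O)CSc3nnc(C)s3)n2-c2ccccc2)cc1` differs from compound 3 by methyl in place of methoxy on an aromatic carbon. Going by the values given here, no measured step covers this exchange. Among the compounds with values here, the one step available is a halogen swap on an aromatic carbon and left the read-out within the scatter, so a similarly small step with no direction beyond the scatter is expected here, namely a number 2.4 percentage points higher from compound 3 to compound 4 (within the scatter). The estimate for compound 4 in this assay is 45%, with a range of 30% to 62%.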

Compound 4, a percentage reported as activity, at one concentration (the size of the read-out at that concentration, not a potency): 50.1%
Compound 4: the middle estimate sits 5.1 percentage points below what was measured; the range from low to high includes it.
By their numbers in this assay, from the lowest: compounds 3 and 4 (each within the scatter of the next); then compounds 2 and 1 (each within the scatter of the next).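

In this assay, the change from 4-methoxyphenyl to 4-methylphenyl, para to a large group, gives a number 7.5 percentage points higher from compound 3 to compound 4 (within the scatter). This extends the earlier picture beyond a halogen swap: an exchange that removes the oxygen of methoxy at this place also stays within the scatter, though on a single pair. Nothing measured here accounts for the size of this step.

Still open, as far as these compounds go, is whether an amine or a carboxylic acid at this place would move the read-out beyond the scatter. Also open, from the compounds shown here alone, is whether the fluoro and bromo pair would behave alike on this core.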